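A few compounds are considered here, and "the series" means these few. Any claim that something is new, unique, unknown or untested is made for them only; others in the source may bear on it.

Working notes on a small set of fused-bicyclic cores bearing a chloromethyl-substituted benzyl group.

Compound 1 `ClCc1ccccc1Cn1cnc2c(Cl)nc(Cl)nc21` carries two chloro groups on the core. In a functional assay on NCI-H322M cells (Homo sapiens) for cytotoxicity, read by sulforhodamine B assay, with a stated time of 48 h (a lower number here means that less compound is tolerated, a higher number that more compound is tolerated), compound 1 gives 5880 nM. Compound 2 `ClCc1ccccc1Cn1cnc2c(Cl)ncnc21` differs from compound 1 only in that one of those chloro groups is replaced by hydrogen, and in this assay compound 2 gives 43700 nM. The change from compound 2 to compound 1 is chloro in place of hydrogen on an aromatic carbon, and the step is a 7.4-fold lower number from compound 2 to compound 1 (0.87 log units; beyond the scatter).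

Compound 3 `ClCc1cccc(Cn2cnc3ncnc(Cl)c32)c1` has the same atoms as compound 2, joined differently; the difference between the two cores is not broken down here. In this assay compound 3 gives 8540 nM, which places it second of the three measured values, within the scatter of compound 1 and beyond the scatter of compound 2.

Compound 4 `ClCc1cccc(Cn2cnc3nc(Cl)nc(Cl)c32)c1` is not yet measured. Relative to compound 3 the change is chloro in place of hydrogen on an aromatic carbon. This is the same change as that made from compound 2 to compound 1, the place lines agreeing word for word, and it occurs twice in all among the compounds shown.

For the measured compounds named here, the step from compound 3 to compound 4 in this assay is expected to resemble the step seen from compound 2 to compound 1, since the only measured instance of this change is a 7.4-fold lower number from compound 2 to compound 1 (0.87 log units; beyond the scatter); the expectation is a 6.1-fold lower number from compound 3 to compound 4 (0.79 log units; beyond the scatter), kept slightly smaller than that measured step, as only one prior instance of this change has been measured. For compound 4 the estimated value in this assay is 1400 nM, with a range from 550 nM to 3800 nM.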

Compound 4, concentration lethal to 50% of the cells: 52500 nM
Compound 4: the middle estimate sits 38-fold (1.57 log units) below what was measured; the whole stated range lies below it.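

In this assay the new step is a 6.1-fold higher number from compound 3 to compound 4 (0.79 log units; beyond the scatter), opposite in direction to the step seen on the other core. Set side by side, the two instances of chloro in place of hydrogen on an aromatic carbon do not carry over from one core to the other: the same change on two cores in this assay, a 7.4-fold lower number (0.87 log units; beyond the scatter) from compound 2 to compound 1 and a 6.1-fold higher number (0.79 log units; beyond the scatter) from compound 3 to compound 4, 46-fold (1.66 log units) apart, beyond the scatter of two such steps. This shows that, for these two cores, the step measured on one did not give even the direction of the step on the other; it does not show which structural difference between the cores goes with the reversal, and with a single pair on each core it says nothing about how the change would behave on any further core.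

The compounds shown leave open whether an amine or a methoxy group in the same place, on an aromatic carbon between two ring nitrogen atoms, would shift the number in opposite directions on the two cores as chloro does. Equally open, from the compounds shown here alone, is what the chloromethyl group contributes on either core, a question that a comparison with a methyl or hydroxymethyl group in its stead would address.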